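The source may report more compounds than this note shows. Statements on the series, on what has been measured and on what is new or still open speak of the compounds shown alone.

Compounds 1 and 2 share one core, seen in compound 1 `COc1ccc(-c2cc3ccccc3c(-c3cccc(O)c3)n2)cc1` and compound 2 `COc1ccc(-c2cc3ccccc3c(-c3cccc(OC)c3)n2)cc1`. In a functional assay on DU-145 cells (Homo sapiens) for cytotoxicity, read by CCK-8 assay and cell counting, with a stated time of 72 h (on this read-out lower numbers stand for stronger inhibition and higher numbers for weaker inhibition), compound 1 gives 5360 nM. Compound 2 reaches only the limit of this assay, at > 50000 nM. The single measured step, an at least 9.3-fold higher number from compound 1 to compound 2 (0.96 log units; beyond the scatter), runs into the limit (the limit of > 50000 nM in this assay, at which 1 of the 2 values shown sits), so compound 2 stands at the weak end of the numbers shown. Compound 3 `COc1ccc(-c2cc3ccccc3c(-c3cccc(N)c3)n2)cc1` carries the change (amino in place of methoxy on an aromatic carbon), read as 3-methoxyphenyl to 3-aminophenyl. The methyl on the oxygen cost potency in the step of an at least 9.3-fold higher number from compound 1 to compound 2 (0.96 log units; beyond the scatter), and the amino of compound 3 points back the other way. For compound 3 the expected step is an at least 6.2-fold lower number from compound 2 to compound 3 (0.79 log units; beyond the scatter), toward stronger inhibition. Compound 3 is estimated at 8000 nM, within 2500 nM to 40000 nM.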

Compound 3, half-maximal inhibitory concentration: 8610 nM
Compound 3: middle estimate off by 1.1-fold (0.03 log units), on the low side; the range from low to high includes it.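

In this assay, amino in place of methoxy gives an at least 5.8-fold lower number from compound 2 to compound 3 (0.76 log units; beyond the scatter), so the weak end of this set is tied to methoxy and not to every replacement of hydroxy at this position. Amino and hydroxy cannot be told apart here, with a 1.6-fold higher number from compound 1 to compound 3 (0.21 log units; within the scatter). The step from compound 2 gives only a bound, since the value of compound 2 is a limit: the limit of > 50000 nM in this assay, at which 1 of the 3 values shown sits.

Open, from the compounds shown here alone, is whether a methylamino group, an acetamido group or a carboxylic acid at this position would stay at the level of compound 1 and compound 3. Also open, going by these compounds, is whether any group here gives a number beyond the scatter from those two.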